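Flipping one ring centre in the unsubstituted amine

A few compounds are considered here, and "the series" means these few. Any claim that something is new, unique, unknown or untested is made for them only; others in the source may bear on it.

Measured compounds:
- compound 2, `NC[C@@H]1NC[C@H](O)[C@@H](O)[C@H]1O`: 9%
- compound 3, `O=C(CCC1CCCC1)NC[C@H]1NC[C@H](O)[C@@H](O)[C@H]1O`: 37%
- compound 1, `COc1ccc(OC)c(/C=C/C(=O)NC[C@H]2NC[C@H](O)[C@@H](O)[C@H]2O)c1`: 57%

Three compounds share a hydroxylated core carrying an aminomethyl group. In an assay on isolated protein for inhibition of alpha-galactosidase (Coffea arabica), read by spectrophotometry, tested at 100 uM (on this read-out lower numbers stand for less inhibition and higher numbers for more inhibition at the one concentration tested (going by the name of the read-out)), compound 2 gives 9%, the lowest of the three numbers; compound 3, with a cyclopentylpropanoyl group on the amine, gives 37%, and compound 1, with a dimethoxyphenyl acrylamide on the amine, gives 57%. Both of these sit beyond the scatter above compound 2.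

Compound 4, `NC[C@H]1NC[C@H](O)[C@@H](O)[C@H]1O`, has not yet been measured. It differs from compound 2 as follows: the two compounds have the same atoms and bonds and differ only in configuration as drawn: 1 of 4 stereo elements differ; a stereocentre at a saturated ring carbon is drawn S in compound 2 and R in compound 4. Among the compounds with values here, no measured pair shows the effect of this change on its own, and the ring configuration of compound 4 matches that drawn in compound 1 and compound 3, which carry acyl groups that compound 4 lacks. The expectation is a small step at most from compound 2, a number 6 percentage points higher from compound 2 to compound 4 (within the scatter), lying within the usual scatter. Compound 4 is therefore estimated at 15%, with a range from 0% to 40%.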

Compound 4, a percentage reported as inhibition, at one concentration (the size of the read-out at that concentration, not a potency): >= 20%
Compound 4 ended at the assay's limit; the forecaster's own chance of this, stated with the estimate: 0%; middle value at least 5 percentage points away from the limit.
By their numbers in this assay, from the lowest: compound 2; then compound 3; then compound 1.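

In this assay, compound 4 gives >= 20%, which is a limit of the assay and not a number. Within the data shown here, until now, no pair of compounds isolated this ring centre, and the new pair gives a number at least 11 percentage points higher from compound 2 to compound 4 (beyond the scatter), so the drawn configuration at this one position can by itself move the read-out beyond the scatter. The step can be tied to that centre alone on this ground: the fact that compounds 2 and 4 differ only in the configuration as drawn.

As far as these compounds go, how far the true step extends stays unknown, and so does the gap between compound 4 and its acylated relatives compound 3 and compound 1, on this ground: the limit of >= 20% in this assay, at which 1 of the 4 values shown sits. From the compounds shown here alone, it also remains open whether a small acetyl group on the amine would raise the read-out, and whether acyl groups would act alike on the ring configuration of compound 2.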